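The compounds below may be only part of what the source reports. "The series", "measured", "known", "first", "only" and "open" are said of these compounds alone.

Within the data shown here, compound 3 `COc1cc(Cl)cc(-c2nn(-c3cccc(NC(=O)Nc4cc(C(F)(F)F)cc(C(F)(F)F)c4)c3)cc2-c2ccncc2)c1` shows the strongest effect of the three compounds measured so far: in a functional assay on SK-OV-3 cells (Homo sapiens) for inhibition, read by sulforhodamine B assay, with a stated time of 48 h, tested at 1 uM (on this read-out higher numbers stand for a weaker effect at the one concentration tested and lower numbers for a stronger effect), compound 3 gives 43%, while compound 1 `O=C(Nc1cccc(-n2cc(-c3ccncc3)c(-c3cc(O)cc(Cl)c3)n2)c1)Nc1ccc(Cl)c(C(F)(F)F)c1` gives 107% and compound 2 `O=C(Nc1cccc(-n2cc(-c3ccncc3)c(-c3cc(O)cc(Cl)c3)n2)c1)Nc1ccc(Cl)c(Cl)c1` gives 110%. Compound 4 `COc1cc(Cl)cc(-c2nn(-c3cccc(NC(=O)Nc4cccc(C(F)(F)F)c4)c3)cc2-c2ccncc2)c1` differs from compound 3 by one change: hydrogen in place of trifluoromethyl on an aromatic carbon. Among the measured compounds shown here, only one measured step touches a trifluoromethyl group, and there the change was small: a number 3 percentage points higher from compound 1 to compound 2 (within the scatter). That step swapped the group for chloro rather than removing it, so it is an imperfect guide. Removing the group outright is expected to cost some of the effect, giving an estimated step of a number 22 percentage points higher from compound 3 to compound 4 (beyond the scatter). Compound 4 is therefore expected to give about 65%, within a range from 35% to 105%.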

Compound 4, a percentage reported as activity, at one concentration (the size of the read-out at that concentration, not a potency): 103%
The estimate for compound 4 lay 38 percentage points below the measured number, within the range that was stated.
By their numbers in this assay, from the lowest: compound 3; then compounds 4, 1 and 2 (each within the scatter of the next).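

In this assay, taking away the trifluoromethyl group that sits meta to the other trifluoromethyl group gives a number 60 percentage points higher from compound 3 to compound 4 (beyond the scatter), so this single group carries much of the effect of compound 3. The earlier step, a number 3 percentage points higher from compound 1 to compound 2 (within the scatter), showed no such change, but it put chloro rather than hydrogen in the group's place, on a pair of compounds with a weak effect. Here, hydrogen at this position leaves little of the effect. As far as these compounds go, whether a methyl group or a nitrile at this position could keep the effect remains open. No measurement shown explains why removing the trifluoromethyl group has so large an effect.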